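The source may report more compounds than this note shows. Statements on the series, on what has been measured and on what is new or still open speak of the compounds shown alone.

Of the compounds shown here, two have numbers so far. In a functional assay on K562 cells (Homo sapiens) for antiproliferative activity, with a stated time of 48 h (a lower number here means a stronger inhibitor, a higher number a weaker inhibitor), compound 1 `Cc1cc(=O)c2c(O)cc(OC[C@H]3CO3)cc2o1` gives 9740 nM. In this assay compound 2 `Cc1cc(=O)c2c(OC[C@@H]3CO3)cc(OC[C@@H]3CO3)cc2o1` gives 19500 nM, and this value lies within the scatter of the number for compound 1, so the data do not separate the two.

The next compound, compound 3 `Cc1cc(=O)c2c(OC[C@@H]3CO3)cc(OC[C@H]3CO3)cc2o1`, has not yet been measured. For the measured compounds named here, it keeps every atom and bond of compound 2, and the only change is one of configuration as drawn: the two compounds have the same atoms and bonds and differ only in configuration as drawn: 1 of 2 stereo elements differ; a stereocentre at a saturated ring carbon is drawn S in compound 2 and R in compound 3.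

Going by the values given here, no measured pair in this set shows what such a change does, so any forecast is cautious. The best guide is compound 2 itself at 19500 nM. No step beyond the scatter is expected in this assay, in either direction. The expected step, a 1.1-fold lower number from compound 2 to compound 3 (0.06 log units; within the scatter), is an estimate that stays within the scatter. For compound 3 the estimated value is 17000 nM, with an expected range of 8000 nM to 35000 nM.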

Compound 3, half-maximal inhibitory concentration: 1490 nM
Estimate against measurement, compound 3: 11-fold (1.06 log units) above; the whole stated range lies above it.
By their numbers in this assay, from the lowest: compound 3; then compounds 1 and 2 (each within the scatter of the next).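

Compounds 1 and 2 had given no step beyond the scatter, so the series had shown nothing that could be read as a real effect of structure. In this assay, compound 3 now shows that this part of the molecule responds strongly to configuration alone, with a 13-fold lower number from compound 2 to compound 3 (1.12 log units; beyond the scatter) at a single saturated ring carbon of an (oxiran-2-yl)methyl group. This step can be assigned to that one stereocentre, drawn S in compound 2 and R in compound 3, because nothing else separates the pair: the fact that compounds 2 and 3 differ only in the configuration as drawn. Placing (oxiran-2-yl)methyl in place of hydrogen on an oxygen on an aromatic ring also counts here, with a 6.5-fold lower number from compound 1 to compound 3 (0.82 log units; beyond the scatter) in the same assay, a smaller step than the one from configuration.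

The compounds shown leave open whether the other stereocentre, drawn alike in compound 2 and compound 3, matters as much as this one. They also leave open whether the oxirane ring itself is needed, as an open-chain diol or an amine at the same place would show.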